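The source may hold more compounds than are shown below. What is called first, only, known or untested is meant among the compounds shown, and "the series" means these compounds.

For the measured compounds named here, in a functional assay on OCI-Ly3 cells (Homo sapiens) for antiproliferative activity (on this read-out higher numbers stand for an effect only at larger amounts of compound and lower numbers for an effect already at smaller amounts), compound 1 `Cc1c(NC(=O)Nc2cnc(-n3nccn3)c(Cl)c2)cnc2ccccc12` gives 7170 nM, the higher of the two numbers so far. Compound 2 `COc1ccc2ncc(NC(=O)Nc3cnc(-n4nccn4)c(Cl)c3)c(C3CC3)c2c1` gives 2390 nM, a lower number by a gap beyond the usual scatter. Compound 3 `COC(C)(C)c1c(NC(=O)Nc2cnc(-n3nccn3)c(Cl)c2)cnc2ccccc12` is still unmeasured and has 1-methoxy-1-methylethyl in place of methyl on an aromatic carbon of compound 1 (1-methoxy-1-methylethyl in place of methyl on an aromatic carbon). Compound 2 at 2390 nM shows that lower numbers occur among these compounds, but no measured pair tests this swap. In this assay a modest step toward a lower number is therefore expected, though a step within the scatter is also possible. The expected step is a 2.0-fold lower number from compound 1 to compound 3 (0.31 log units; beyond the scatter). For compound 3 the estimated value is 3500 nM, with a range of 900 nM to 12000 nM.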

Compound 3, half-maximal effective concentration: 4430 nM
Beside the measured number, compound 3's estimate is 1.3-fold (0.10 log units) below it; low and high end bracket the measured number.
By their numbers in this assay, from the lowest: compounds 2, 3 and 1 (each within the scatter of the next, the first and the last beyond it).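

In this assay, 1-methoxy-1-methylethyl in place of methyl on this aromatic carbon, opposite the ring nitrogen, gives a 1.6-fold lower number from compound 1 to compound 3 (0.21 log units; within the scatter). The step lies within the usual scatter, so this read-out does not separate the two groups, even though the entering group is much larger and carries an oxygen. No supporting measurement bears on why this is so. On these data alone, what stays open is whether an amine, a carboxylic acid or a longer chain on this carbon would give a number clearly apart from that of compound 1.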